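Methyl to Methoxy on the Pendant Ring: Expected Cytotoxicity

The compounds below may be only part of what the source reports. "The series", "measured", "known", "first", "only" and "open" are said of these compounds alone.

Measured compounds:
- compound 1, `Cc1noc2c(C(c3ccccc3)c3c(-c4ccccc4)c[n+]([O-])c4c(C)noc34)c(-c3ccccc3)c[n+]([O-])c12`: 26.6 ug/mL
- compound 2, `Cc1ccccc1C(c1c(-c2ccccc2)c[n+]([O-])c2c(C)noc12)c1c(-c2ccccc2)c[n+]([O-])c2c(C)noc12`: 65.1 ug/mL

In a functional assay on Ehrlich cells (Homo sapiens) for cytotoxicity, read by MTT assay, with a stated time of 48 h (a higher number here means a weaker inhibitor, a lower number a stronger inhibitor), compound 1 gives 26.6 ug/mL, and compound 2 gives 65.1 ug/mL, the higher of the two numbers. Going by the values given here, the only measured step is a 2.4-fold higher number from compound 1 to compound 2 (0.39 log units; beyond the scatter). Compound 3, `COc1ccccc1C(c1c(-c2ccccc2)c[n+]([O-])c2c(C)noc12)c1c(-c2ccccc2)c[n+]([O-])c2c(C)noc12`, carries methoxy in place of methyl on an aromatic carbon. Among the compounds with values here, no measured step shows a methoxy entering, so the expectation rests on the single measured step alone, and the change is expected to stay within the scatter: a 1.1-fold higher number from compound 2 to compound 3 (0.03 log units; within the scatter). Compound 3 is therefore estimated at 70 ug/mL, within 30 ug/mL to 160 ug/mL.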

Compound 3, half-maximal inhibitory concentration: 51.9 ug/mL
For compound 3 the middle estimate is 1.3-fold (0.13 log units) above the measured one; measured number inside the range.
By their numbers in this assay, from the lowest: compounds 1, 3 and 2 (each within the scatter of the next, the first and the last beyond it).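

In this assay, replacing 2-methylphenyl with 2-methoxyphenyl gives a 1.3-fold lower number from compound 2 to compound 3 (0.10 log units; within the scatter), so at this place, ortho to a large group, the two groups cannot be told apart. Measured against hydrogen at the same carbon, methoxy gives a 2.0-fold higher number from compound 1 to compound 3 (0.29 log units; within the scatter), whereas only the methyl step from hydrogen is printed as beyond the scatter. No evidence is available that bears on either step.

Still open, on these data alone, is how a chlorine atom or an amine would read at this place, and whether any group here would give a lower number than hydrogen.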